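Swapping a dichlorophenyl for a fluorophenyl on a shared core

The source may hold more compounds than are shown below. What is called first, only, known or untested is meant among the compounds shown, and "the series" means these compounds.

Of the compounds shown here, three that share one core have been tested in a functional assay on 786-0 cells (Homo sapiens) for inhibition, read by sulforhodamine B assay, with a stated time of 48 h; a higher number here means a weaker inhibitor of growth, a lower number a stronger inhibitor of growth. Compound 1 `Nc1cc(N)c2nc(-c3ccccc3)c(NCc3ccc(Cl)c(Cl)c3)nc2c1` gives 13200 nM. Compound 2 `COc1cc(CNc2nc3cc(N)cc(N)c3nc2-c2ccccc2)cc(OC)c1OC` gives 15500 nM, and compound 3 `CCOC(=O)[C@H](CCC(=O)O)NC(=O)c1ccc(Oc2nc3cc(N)cc(N)c3nc2-c2ccccc2)cc1` gives 15500 nM. Compound 1 has the lowest of the three numbers, yet the other two lie within the usual scatter of it, so no order among them can be read. Compound 4 `Nc1cc(N)c2nc(-c3ccccc3)c(NCc3ccc(F)cc3)nc2c1` has not been measured; it differs from compound 1 by 4-fluorophenyl in place of 3,4-dichlorophenyl on a saturated chain carbon bound to a nitrogen on an aromatic ring. Among the measured compounds shown here, no measured pair shows what such a change does here. In this assay the expected step is a 1.5-fold higher number from compound 1 to compound 4 (0.18 log units; within the scatter), small, and if anything towards a higher number. Compound 4 is therefore estimated at 20000 nM, with a range from 7000 nM to 60000 nM.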

Compound 4, concentration for 50% growth inhibition: 23400 nM
For compound 4 the middle estimate is 1.2-fold (0.07 log units) below the measured one, and the stated range covers the measured number.
By their numbers in this assay, from the lowest: compounds 1, 2, 3 and 4 (each within the scatter of the next).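

The first pair differing in one place shows that 4-fluorophenyl in place of 3,4-dichlorophenyl on this saturated chain carbon gives a 1.8-fold higher number from compound 1 to compound 4 (0.25 log units; within the scatter) in this assay and so leaves growth inhibition without a readable change. At this position, losing both chlorines and adding a fluorine does not separate the two compounds. No further measurement is available to explain this result.

From the compounds shown here alone, it remains open whether a more different group here would separate from compound 1. An amine or carboxylic acid on the phenyl ring, or a longer chain in place of the saturated chain carbon, could test that.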